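A few compounds are considered here, and "the series" means these few. Any claim that something is new, unique, unknown or untested is made for them only; others in the source may bear on it.

Working notes on the series. For the measured compounds named here, compound 1 `COc1ccc2cc([C@H](C)c3nnc(SCc4c(C)cc(C)cc4C)n3-c3cccc(Cl)c3)ccc2c1` is the only member with a full number: in a functional assay on PC-3 cells (Homo sapiens) for cytotoxicity, read by MTT assay (a lower number here means a stronger inhibitor, a higher number a weaker inhibitor), compound 1 gives 16300 nM. Compound 2 `COc1ccc(CSc2nnc([C@@H](C)c3ccc4cc(OC)ccc4c3)n2-c2ccc(Cl)cc2)cc1` has no number of its own in this assay; for compound 2 only a limit of <= 400000 nM is reported, and this limit of <= 400000 nM in this assay, at which 1 of the 2 values shown sits, is where compound 2 stands, so it cannot be ranked against compound 1 beyond what the two values show.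

Compound 3 `COc1ccc2cc([C@H](C)c3nnc(SCc4c(Cl)cccc4Cl)n3-c3ccc(Cl)cc3)ccc2c1` is not yet measured in this assay. Relative to compound 2 the change is 2,6-dichlorophenyl in place of 4-methoxyphenyl on a saturated chain carbon bound to a sulfur. With compound 2 known only as a limit, no step size can be counted from it; the expected step from compound 2 to compound 3 is written as a step that the limit leaves unreadable from compound 2 to compound 3, meaning compound 3 is expected to come in with a real number rather than a limit. Taking compound 1 at 16300 nM as the nearest measured point, compound 3 is estimated at 30000 nM, in the range 8000 nM to 150000 nM.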

Compound 3, half-maximal inhibitory concentration: 34700 nM
Beside the measured number, compound 3's estimate is 1.2-fold (0.06 log units) below it; the range from low to high includes it.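

No step can be read from compound 2 to compound 3, as compound 2 is known only as a limit and not as a number: the limit of <= 400000 nM in this assay, at which 1 of the 3 values shown sits.

The compounds shown leave open how 2,6-dichlorophenyl and 4-methoxyphenyl compare on a saturated chain carbon bound to a sulfur in this assay.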